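Hydroxy for Bromo on the Seven-Membered Ring

The source may report more compounds than this note shows. Statements on the series, on what has been measured and on what is new or still open speak of the compounds shown alone.

Compound 2 `CCOC(=O)C(=O)Nc1ccccc(Br)c1=O` gives 52% in a functional assay on the whole organism (strain Sprague-Dawley CD) for inhibition, with Rattus norvegicus as the target, read by paw edema, at a dose of 30 mg/kg by the intraperitoneal route (on this read-out lower numbers stand for a weaker effect and higher numbers for a stronger effect at the one dose given), and this stands within the scatter of compound 1 `CCOC(=O)C(=O)Nc1ccccc(C)c1=O`, which gives 60% in this assay. Compound 3 `CCOC(=O)C(=O)Nc1ccccc(O)c1=O` differs from compound 2 by hydroxy in place of bromo on an aromatic carbon. Going by the values given here, the only measured step, a number 8 percentage points lower from compound 1 to compound 2 (within the scatter), concerns a different group entering at the same place and offers limited guidance. Among the compounds with values here, no measured step speaks for hydroxy. For compound 3 the expected step is no change at the digits printed from compound 2 to compound 3 (within the scatter), with none beyond the scatter anticipated. The estimate for compound 3 is 52%, ranging from 30% to 70%.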

Compound 3, a percentage reported as inhibition, in the whole organism at one dose (the size of the read-out at that dose, not a potency): 61%
The estimate for compound 3 lay 9 percentage points below the measured number; the measured number falls inside the stated range.
By their numbers in this assay, from the lowest: compounds 2, 1 and 3 (each within the scatter of the next).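

Hydroxy in place of bromo brings a number 9 percentage points higher from compound 2 to compound 3 (within the scatter) and hydroxy in place of methyl brings a number 1 percentage points higher from compound 1 to compound 3 (within the scatter) in this assay on this aromatic carbon of the seven-membered ring. This place therefore now carries a group with a hydrogen-bond donor, and at the one dose given the read-out does not separate hydroxy, bromo and methyl. Nothing available here explains this result. On these data alone, whether an amine, a carboxylic acid or a longer chain at this place would give a number beyond the scatter stays open.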